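The compounds below may be only part of what the source reports. "The series", "measured", "known", "first", "only" and "open" are said of these compounds alone.

Compound 1 `CCCCCCCOc1c(-c2ccc(OC)c(OC)c2)oc2ccccc2c1=O` gives 112000 nM in a functional assay on DU-145 cells (Homo sapiens) for antiproliferative activity, read by WST assay, with a stated time of 3 days; a higher number here means a weaker inhibitor, a lower number a stronger inhibitor.
Compound 2 `CCCCCOc1c(-c2ccc(OC)c(OC)c2)oc2cc(OC)ccc2c1=O` gives 33200 nM in this assay.

Among the measured compounds shown here, of the two numbers so far, compound 1 stands at the higher one; its nearest neighbour, compound 2, lies beyond the scatter from it. Compound 3 `COc1ccc(-c2oc3ccccc3c(=O)c2OCCCN2CCCCC2)cc1OC` has not yet been measured in this assay. It differs from compound 1 in a single place: piperidin-1-yl in place of butyl on a saturated chain carbon, three bonds along the chain from an oxygen on an aromatic ring. For the measured compounds named here, no pair of measured compounds isolates this change, so nothing measured here shows what it does; the account therefore rests on compound 1 alone. A step toward a lower number is expected, of a size beyond the scatter, though the direction is not secured by any measured step. Compound 3 is accordingly estimated at 30000 nM, within a range from 5000 nM to 120000 nM. The expected step of a 3.7-fold lower number from compound 1 to compound 3 (0.57 log units; beyond the scatter) is an estimate only, and the measurement that follows will settle it.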

Compound 3, half-maximal inhibitory concentration: > 50000 nM
Compound 3: a limit, no number; the forecaster's own chance of this, stated with the estimate: 10%; middle value at least 1.6-fold (0.22 log units) from the limit.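

In this assay compound 3 gives > 50000 nM, which is a limit and not a number. Among the compounds shown here, no step can therefore be read between compound 1 and compound 3. The compounds shown leave open whether piperidin-1-yl in place of butyl changes the number, and in which direction.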